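The source may report more compounds than this note shows. Statements on the series, on what has been measured and on what is new or still open speak of the compounds shown alone.

Compound 1 `N=C(N)NCCCN(CC(=O)N[C@@H](CCCCN)C(=O)N[C@@H](C(N)=O)c1ccccc1)C(=O)c1ccccc1` reads only as the limit of the assay, <= 5%.
Compound 2 `C[C@](NC(=O)[C@H](CCCCN)NC(=O)[C@H](CCCNC(=N)N)NC(=O)c1ccccc1)(C(N)=O)c1ccccc1` gives 11.8% in an assay on isolated protein for inhibition of Trypsin (Homo sapiens), read by fluorescence, with a stated time of 15 min, tested at 50 uM; on this read-out lower numbers stand for less inhibition and higher numbers for more inhibition at the one concentration tested (going by the name of the read-out).
Compound 3 `N=C(N)NCCC[C@H](NC(=O)c1ccccc1)C(=O)N[C@@H](CCCCN)CC(=O)N[C@@H](C(N)=O)c1ccccc1` also reads only as the limit of the assay, <= 5%.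

Among the compounds with values here, compound 2 thus stands as the one measured compound with an actual number; the other two sit at the limit of <= 5% in this assay, at which 2 of the 3 values shown sit. Compound 4 `CCC(NC(=O)[C@H](CCCCN)NC(=O)[C@H](CCCNC(=N)N)NC(=O)c1ccccc1)(C(N)=O)c1ccccc1` is not yet measured. It differs from compound 2 by one change, (1-carbamoyl-1-phenylpropyl in place of 1-carbamoyl-1-phenylethyl on an amide-type nitrogen). Within the data shown here, no step between two measured compounds is available to show what such a change does in this assay, so the expectation rests on compound 2 alone. The change is small, and the step from compound 2 to compound 4 is expected to be a number 1.8 percentage points lower from compound 2 to compound 4 (within the scatter), not beyond the usual scatter. Compound 4 is estimated at 10%, with a range from 3% to 22%.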

Compound 4, a percentage reported as inhibition, at one concentration (the size of the read-out at that concentration, not a potency): 8.7%
Compound 4: the middle estimate sits 1.3 percentage points above what was measured; measured number inside the range.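

At this position, the first readable step shows that 1-carbamoyl-1-phenylpropyl in place of 1-carbamoyl-1-phenylethyl on an amide-type nitrogen gives a number 3.1 percentage points lower from compound 2 to compound 4 (within the scatter) in this assay. The longer group therefore makes no difference that can be told from the usual scatter. Neither compound 2 nor compound 4 sits at the limit of this read-out: the limit of <= 5% in this assay, at which 2 of the 4 values shown sit.

As far as these compounds go, whether a butyl chain, an amine or a carboxylic acid on this carbon would shift the number beyond the scatter stays open. From the compounds shown here alone, how these compounds behave at other concentrations also stays open.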